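A few compounds are considered here, and "the series" means these few. Any claim that something is new, unique, unknown or untested is made for them only; others in the source may bear on it.

Of the compounds shown here, three with one shared core have been tested so far, and all sit at the floor of the read-out. Compound 1 `Cc1c(-c2ccccc2)sc(N)c1C(=O)c1ccc(Cl)cc1` is the plainest of them; in an assay on CHO cells for displacement of a labelled ligand from adenosine receptor A1 (Homo sapiens), read by scintillation counting, tested at 10 uM (on this read-out lower numbers stand for less inhibition and higher numbers for more inhibition at the one concentration tested (going by the name of the read-out)), compound 1 gives 1%. Compound 2 `COc1ccc(-c2sc(N)c(C(=O)c3ccc(Cl)cc3)c2C)cc1` adds a methoxy on an aromatic carbon, and in this assay compound 2 gives 1%, so that no change at the digits printed from compound 1 to compound 2 (within the scatter). Compound 3 `CC(C)(C)Cc1c(-c2ccoc2)sc(N)c1C(=O)c1ccc(Cl)cc1` carries a neopentyl group and a furan-3-yl on its core, and in this assay compound 3 gives 1%; its value is level with those of compound 1 and compound 2, and all three lie within the scatter of one another.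

Compound 4 `CC(C)(C)Cc1c(-c2cccnc2)sc(N)c1C(=O)c1ccc(Cl)cc1` is the next one to be tested. It differs from compound 3 in one place: pyridin-3-yl in place of furan-3-yl on an aromatic carbon.

Going by the values given here, none of the measured steps touches this position; the one step seen, from a hydrogen to a methoxy, lay elsewhere on the core and moved nothing beyond the scatter. Among the compounds with values here, every compound measured so far gives essentially no inhibition, and nothing in the data points to a departure from that. The step expected is therefore a number 1 percentage points higher from compound 3 to compound 4 (within the scatter), none beyond the scatter. Compound 4 is expected to give 2%, within a range from 0% to 12%.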

Compound 4, a percentage reported as inhibition, at one concentration (the size of the read-out at that concentration, not a potency): 1%
Estimate against measurement, compound 4: 1 percentage points above; measured number inside the range.
By their numbers in this assay, from the lowest: compounds 1, 2, 3 and 4 (each within the scatter of the next).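

In this assay, putting pyridin-3-yl in place of furan-3-yl, on the aromatic carbon next to the ring sulfur and next to the ring atom that bears a neopentyl group, gives no change at the digits printed from compound 3 to compound 4 (within the scatter). Going by these compounds alone, this is the first step measured at this position, and it shows that a five-membered aromatic ring with an oxygen and a six-membered aromatic ring with a nitrogen cannot be told apart here at the one concentration tested, at least with the neopentyl group in place. No supporting measurement is available to explain this result.

Within the data shown here, because both compounds sit at the floor of the read-out, this step cannot show whether either ring helps or harms, only that the swap produces no inhibition that rises above the scatter. Going by these compounds, it remains open whether a different group on this aromatic carbon, such as a carboxylic acid or a simple amine, would raise the number, and whether a longer straight chain in place of the neopentyl group would allow any ring here to do so.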